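Methoxy extension on the dimethylbenzothiazole amide

The source may hold more compounds than are shown below. What is called first, only, known or untested is meant among the compounds shown, and "the series" means these compounds.

Compound 1 `COc1ccc(-c2cc(C(=O)Nc3nc4ccc(OC)cc4s3)nc3cc(-c4ccccc4)nn23)cc1` gives 7580 nM in a functional assay on DU-145 cells (Homo sapiens) for cytotoxicity, read by MTT assay, with a stated time of 48 h; on this read-out lower numbers stand for stronger inhibition and higher numbers for weaker inhibition. Compound 2 `COc1ccc2nc(NC(=O)c3cc(-c4ccc(OC)c(OC)c4)n4nc(-c5ccccc5)cc4n3)sc2c1` gives 14000 nM in this assay; its difference from compound 1 is methoxy in place of hydrogen on an aromatic carbon, with a 1.8-fold higher number from compound 1 to compound 2 (0.27 log units; within the scatter). Compound 3 `COc1ccc(-c2cc(C(=O)Nc3nc4cc(C)c(C)cc4s3)nc3cc(-c4ccccc4)nn23)cc1` differs from compound 1 by 5,6-dimethyl-1,3-benzothiazol-2-yl in place of 6-methoxy-1,3-benzothiazol-2-yl on an amide-type nitrogen, with a 1.6-fold higher number from compound 1 to compound 3 (0.21 log units; within the scatter). In this assay compound 3 gives 12300 nM. Compound 4 `COc1ccc(-c2cc(C(=O)Nc3nc4cc(C)c(C)cc4s3)nc3cc(-c4ccccc4)nn23)cc1OC` is not yet measured; its difference from compound 3 is methoxy in place of hydrogen on an aromatic carbon, the same change as that made from compound 1 to compound 2, the surroundings of the place being described in the same words. The step from compound 3 to compound 4 in this assay is expected to be a 1.6-fold higher number from compound 3 to compound 4 (0.21 log units; within the scatter), set beside the earlier one, because a 1.8-fold higher number from compound 1 to compound 2 (0.27 log units; within the scatter) stayed within the scatter and the two cores differ only by 5,6-dimethyl-1,3-benzothiazol-2-yl in place of 6-methoxy-1,3-benzothiazol-2-yl on an amide-type nitrogen. Compound 4 is accordingly estimated at 20000 nM, within 9000 nM to 45000 nM.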

Compound 4, half-maximal inhibitory concentration: 6910 nM
For compound 4 the middle estimate is 2.9-fold (0.46 log units) above the measured one; the whole stated range lies above it.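

In this assay the change from 4-methoxyphenyl to 3,4-dimethoxyphenyl on the core bearing 5,6-dimethyl-1,3-benzothiazol-2-yl gives a 1.8-fold lower number from compound 3 to compound 4 (0.25 log units; within the scatter), and it does not carry over unchanged from the core of compound 1: the same change on two cores in this assay, a 1.8-fold higher number (0.27 log units; within the scatter) from compound 1 to compound 2 and a 1.8-fold lower number (0.25 log units; within the scatter) from compound 3 to compound 4, 3.3-fold (0.52 log units) apart, beyond the scatter of two such steps

The exchange of 6-methoxy-1,3-benzothiazol-2-yl for 5,6-dimethyl-1,3-benzothiazol-2-yl, read on the 3,4-dimethoxyphenyl compounds, gives a 2.0-fold lower number from compound 2 to compound 4 (0.31 log units; beyond the scatter), and it too differs from its counterpart: the same change on two cores in this assay, a 1.6-fold higher number (0.21 log units; within the scatter) from compound 1 to compound 3 and a 2.0-fold lower number (0.31 log units; beyond the scatter) from compound 2 to compound 4, 3.3-fold (0.52 log units) apart, beyond the scatter of two such steps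

The two changes therefore do not combine independently across these four compounds, but this rests on a single set of four, so it gives no cause for the difference and no rule for other cores.

Still open, as far as these compounds go, is how a hydroxy group, an ethoxy group or an amine at the same place would read on each core. Also open, from the compounds shown here alone, is whether the same mismatch between steps appears with other groups on the benzothiazole.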